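Side-Chain Variation at the Amide-Bearing Carbon

The source may report more compounds than this note shows. Statements on the series, on what has been measured and on what is new or still open speak of the compounds shown alone.

For the measured compounds named here, in a functional assay on MCF7 cells (Homo sapiens) for cytotoxicity, read by MTT assay, with a stated time of 24 h (on this read-out lower numbers stand for stronger inhibition and higher numbers for weaker inhibition), compound 2 `COC(=O)[C@H](NC(=O)Cn1cc(C2=C(c3c[nH]c4ccccc34)C(=O)N(C)C2=O)c2ccccc21)[C@@H](C)O` gives 22900 nM, the lower of the two numbers so far, yet it sits within the scatter of compound 1 `COC(=O)[C@@H](CC(C)C)NC(=O)Cn1cc(C2=C(c3c[nH]c4ccccc34)C(=O)N(C)C2=O)c2ccccc21`, which gives 37400 nM. Going by the values given here, the single measured step at this place, a 1.6-fold lower number from compound 1 to compound 2 (0.21 log units; within the scatter), shows no shift beyond the scatter. Compound 3 `COC(=O)CC[C@@H](NC(=O)Cn1cc(C2=C(c3c[nH]c4ccccc34)C(=O)N(C)C2=O)c2ccccc21)C(=O)OC` differs from compound 2 by 2-(methoxycarbonyl)ethyl in place of 1-hydroxyethyl on a saturated chain carbon bound to an amide-type nitrogen and a carbonyl carbon. Among the compounds with values here, no measured step covers this particular change, and the one change already tried at the same place stayed within the scatter, so compound 3 is expected to show a 1.1-fold higher number from compound 2 to compound 3 (0.04 log units; within the scatter), no move beyond the scatter. Compound 3 is therefore estimated at 25000 nM, within a range from 9000 nM to 70000 nM.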

Compound 3, half-maximal inhibitory concentration: 23400 nM
Compound 3: middle estimate off by 1.1-fold (0.03 log units), on the high side; the measured number falls inside the stated range.
By their numbers in this assay, from the lowest: compounds 2, 3 and 1 (each within the scatter of the next).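

In this assay, 2-(methoxycarbonyl)ethyl in place of 1-hydroxyethyl gives a 1.0-fold higher number from compound 2 to compound 3 (0.01 log units; within the scatter), and the comparison with the isobutyl compound gives a 1.6-fold lower number from compound 1 to compound 3 (0.20 log units; within the scatter). A side chain of 6 heavy atoms with 0 hydrogen-bond donors therefore leaves the number within the scatter, so all three side chains at this place remain indistinguishable. Nothing available explains this result.

Going by these compounds, whether a free carboxylic acid or a primary amine at the end of this side chain would move the number beyond the scatter remains open.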